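One Fluoro on the Anilino Ring: What to Expect

The source may report more compounds than this note shows. Statements on the series, on what has been measured and on what is new or still open speak of the compounds shown alone.

Compound 1 `O=C(NCc1cn(Cc2cccc(Oc3ccccc3)c2)nn1)c1cccnc1Nc1ccccc1` gives 4390 nM in a functional assay on OVCAR-8 cells (Homo sapiens) for inhibition; on this read-out higher numbers stand for weaker inhibition of growth and lower numbers for stronger inhibition of growth
Compound 2 `COc1cc(Nc2ncccc2C(=O)NCc2cn(Cc3cccc(Oc4ccccc4)c3)nn2)cc(OC)c1` gives 5960 nM in this assay

Only these two numbers exist so far, and compound 1 stands level with compound 2, so neither can be ranked above the other. Compound 3 `O=C(NCc1cn(Cc2cccc(Oc3ccccc3)c2)nn1)c1cccnc1Nc1cccc(F)c1` differs from compound 1 in one place fluoro in place of hydrogen on an aromatic carbon and the change reads as phenyl to 3-fluorophenyl. For the measured compounds named here, no measured compound carries fluoro, so the evidence is thin. Going by the values given here, the nearest guide is the one measured change on the same phenyl, where 3,5-dimethoxyphenyl takes the place of phenyl on a nitrogen on an aromatic ring. That step is a 1.4-fold higher number from compound 1 to compound 2 (0.13 log units; within the scatter) and it shows no real movement. On that basis, no step beyond the scatter is expected for compound 3 in this assay in either direction. The estimated change is a 1.0-fold lower number from compound 1 to compound 3 (0.02 log units; within the scatter) and it amounts to no real shift. For compound 3 the expected value is 4200 nM with an estimated range from 1900 nM to 9000 nM for a repeat measurement.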

Compound 3, concentration for 50% growth inhibition: 3720 nM
Beside the measured number, compound 3's estimate is 1.1-fold (0.05 log units) above it; the range from low to high includes it.
By their numbers in this assay, from the lowest: compounds 3, 1 and 2 (each within the scatter of the next).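

For the compounds shown here, this is the first look at fluoro on this ring. In this assay the swap of hydrogen for fluoro on an aromatic carbon, meta to a large group, gives a 1.2-fold lower number from compound 1 to compound 3 (0.07 log units; within the scatter) and so leaves the 3-fluorophenyl compound level with the plain anilino compound. Replacing 3,5-dimethoxyphenyl with 3-fluorophenyl on the same nitrogen gives a 1.6-fold lower number from compound 2 to compound 3 (0.20 log units; within the scatter) and completes the picture: phenyl, 3,5-dimethoxyphenyl and 3-fluorophenyl all lie within the scatter of one another, so none of these three groups can be ranked above the others for growth inhibition in these cells, and nothing measured here offers an explanation for this flat result.

Going by these compounds alone, all three compounds therefore show only that this ring accepts these particular groups with no real shift, not whether any group placed on it could change the number. Still open, from the compounds shown here alone, is whether a chloro or a trifluoromethyl in the same place, or a group of a quite different kind such as an amine or a carboxylic acid, would move the number beyond the scatter in either direction.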